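This account rests on a few compounds, and the source may have more. Where it says the series, first, only, none or still open, it means among the compounds named here.

Measured compounds:
compound 1, `CC(C)N1CCN(Cc2csc(N)c2C(=O)c2ccc(Cl)cc2)CC1`: -7.4%
compound 2, `Nc1scc(CN2CCN(c3cc(Cl)cc(Cl)c3)CC2)c1C(=O)c1ccc(Cl)cc1`: -74%

Both were read in a functional assay on CHO cells with adenosine receptor A1 (Homo sapiens) as the target, read by cAMP accumulation and immunoassay, with a stated time of 6 min, tested at 10 uM; on this read-out higher numbers stand for a weaker effect at the one concentration tested and lower numbers for a stronger effect. Compound 2 gives -74%, the lowest of the two numbers; its nearest neighbour is compound 1, which gives -7.4%. Going by the values given here, the single measured step, a number 66.6 percentage points lower from compound 1 to compound 2 (beyond the scatter), is large. Compound 3, `Nc1scc(CN2CCN(c3ccc(Cl)c(C(F)(F)F)c3)CC2)c1C(=O)c1ccc(Cl)cc1`, has not yet been measured. It differs from compound 2 in one place: 4-chloro-3-(trifluoromethyl)phenyl in place of 3,5-dichlorophenyl on an amine nitrogen in a ring. Among the compounds with values here, no measured step bears directly on this change: the step from compound 1 to compound 2 put 3,5-dichlorophenyl in place of isopropyl, whereas here one six-membered aromatic ring of carbon only replaces another on the same ring nitrogen. Within the data shown here, with only that one step to go on, a change in this assay no larger than the scatter is expected, in no particular direction. Compound 3 is therefore estimated at -65%, within -95% to -25%. This corresponds to an expected step of a number 9 percentage points higher from compound 2 to compound 3 (within the scatter).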

Compound 3, a percentage reported as activity, at one concentration (the size of the read-out at that concentration, not a potency): -60%
Estimate against measurement, compound 3: 5 percentage points below, within the range that was stated.
By their numbers in this assay, from the lowest: compound 2; then compound 3; then compound 1.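

Here this assay shows a number 14 percentage points higher from compound 2 to compound 3 (beyond the scatter) when 4-chloro-3-(trifluoromethyl)phenyl replaces 3,5-dichlorophenyl on the amine nitrogen in the ring, so these two aromatic groups are not interchangeable at this position. The second aromatic group also stands well apart from isopropyl, with a number 52.6 percentage points lower from compound 1 to compound 3 (beyond the scatter) for that exchange, so the large step first seen with 3,5-dichlorophenyl is not confined to that one group. Nothing measured here explains the difference between the two aromatic groups.

The trifluoromethyl and the chlorine pattern change together between compound 2 and compound 3, so the compounds shown do not separate their contributions. Going by these compounds, how a plain phenyl, a pyridine ring or a benzyl group on the same nitrogen would read also remains open.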